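This account rests on a few compounds, and the source may have more. Where it says the series, first, only, none or still open, it means among the compounds named here.

Measured compounds:
compound 1, `CC(C)c1ccc(/C=N/NC(=O)CSc2nnnn2C)cc1`: 400000 nM in a functional assay on A549 cells (Homo sapiens) for cytotoxicity, read by XTT assay, with a stated time of 24 h; a lower number here means a stronger inhibitor, a higher number a weaker inhibitor
compound 2, `C/C(=N\NC(=O)CSc1nnnn1C)c1ccccc1Cl`: 6320000 nM in this assay

Of these two numbers, compound 2 stands at the highest, so it is the weaker of the pair, and the gap to compound 1 lies beyond the usual scatter of such measurements. Compound 3, `C/C(=N\NC(=O)CSc1nnnn1C)c1ccc(Cl)cc1`, has not yet been measured in this assay. It is built from the same atoms as compound 2, joined differently: 4-chlorophenyl in place of 2-chlorophenyl on a carbon with a double bond to nitrogen. For the measured compounds named here, no step between two measured compounds isolates this change, so its effect can only be guessed from what the two measured numbers show. Both of them are high, and compound 2 is already close to the range where an assay may report only a limit. The change to compound 3 is expected to move the number down rather than up, by a step roughly the size of the scatter or a little beyond it, because compound 1 gives 400000 nM and shows that this core can reach lower numbers. For compound 3 the expected value in this assay is 1500000 nM, within a range of 300000 nM to 8000000 nM. That estimate corresponds to an expected step of a 4.2-fold lower number from compound 2 to compound 3 (0.62 log units; beyond the scatter).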

Compound 3, half-maximal inhibitory concentration: 6000000 nM
Beside the measured number, compound 3's estimate is 4.0-fold (0.60 log units) below it; low and high end bracket the measured number.
By their numbers in this assay, from the lowest: compound 1; then compounds 3 and 2 (each within the scatter of the next).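

In this assay, putting 4-chlorophenyl in place of 2-chlorophenyl on a carbon with a double bond to nitrogen gives a 1.1-fold lower number from compound 2 to compound 3 (0.02 log units; within the scatter) and so the two compounds cannot be told apart. For the compounds shown here, this is the first direct comparison at this position, and it shows that, for this pair, the place of the chlorine on the phenyl ring does not separate the two numbers, with both compounds remaining very weak in this cytotoxicity test. No separate measurement on these compounds offers an explanation for how close the two numbers lie.

The compounds shown leave open whether a different kind of group in place of the chlorine, such as a methoxy group, an amine or a carboxylic acid, would give a number clearly apart from these two. They also leave open what the methyl group on the carbon with a double bond to nitrogen contributes, as compound 1 differs from compound 2 in more than one place and that pair cannot isolate a single change.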